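Swapping Piperidin-1-yl for 4-Allylpiperazin-1-yl

The source may hold more compounds than are shown below. What is called first, only, known or untested is meant among the compounds shown, and "the series" means these compounds.

Of the compounds shown here, three built on a shared core have been measured in a functional assay on A549 cells (Homo sapiens) for antiproliferative activity, read by MTT assay, with a stated time of 48 h; a higher number here means a weaker inhibitor, a lower number a stronger inhibitor. In this assay, compound 1 (`O=C(Nc1cccc(Cl)c1)Nc1cccc(NC(=O)c2ccccn2)c1`) gives 2850 nM, compound 2 (`O=C(Nc1cccc(NC(=S)Nc2ccc([N+](=O)[O-])cc2)c1)c1ccccn1`) gives 450 nM, and compound 3 (`O=C(CSC(=S)N1CCCCC1)Nc1cccc(NC(=O)c2ccccn2)c1`) gives 320 nM. Compound 3 and compound 2 lie within the usual scatter of each other, so neither can be ranked above the other. Compound 3 does stand clearly below compound 1, which places it in the stronger pair of this small set.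

Compound 4 (`C=CCN1CCN(C(=S)SCC(=O)Nc2cccc(NC(=O)c3ccccn3)c2)CC1`) has not yet been measured. It differs from compound 3 only in the group on a thiocarbonyl carbon whose other neighbour is sulfur: 4-allylpiperazin-1-yl in place of piperidin-1-yl on a thiocarbonyl carbon. The six-membered non-aromatic ring remains, but it now holds a second hetero atom and carries a double bond outside aromatic rings.

For the measured compounds named here, no two measured compounds differ in one place, so the data give no direct measure of a swap like this one. With compound 3 at 320 nM as the nearest reference, no step beyond the scatter is expected in this assay. The expected step is a 1.1-fold lower number from compound 3 to compound 4 (0.03 log units; within the scatter). Compound 4 is estimated at 300 nM, with an expected range from 110 nM to 850 nM.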

Compound 4, half-maximal inhibitory concentration: 210 nM
The estimate for compound 4 lay 1.4-fold (0.15 log units) above the measured number, and the stated range covers the measured number.
By their numbers in this assay, from the lowest: compounds 4, 3 and 2 (each within the scatter of the next, the first and the last beyond it); then compound 1.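

In this assay, the swap gives a 1.5-fold lower number from compound 3 to compound 4 (0.18 log units; within the scatter), so compound 3 and compound 4 cannot be ranked against each other. For the compounds shown here, this is the first direct reading of any single change, and it shows that the group on a thiocarbonyl carbon whose other neighbour is sulfur can be altered considerably without a step beyond the scatter: the piperidin-1-yl group of 6 heavy atoms gives way to the 4-allylpiperazin-1-yl group of 9 heavy atoms, which adds a second hetero atom to the ring, a double bond outside aromatic rings and a hydrogen-bond acceptor. Nothing available explains why the number stays within the scatter across this change, and no measurement of any property of these groups bears on it.

With both changes made in one step, the compounds shown do not separate any contribution of the second ring nitrogen from that of the allyl group. Going by these compounds, it also remains open whether an unsubstituted piperazin-1-yl group, a morpholin-4-yl group or an open-chain diethylamino group at this place would stay within the scatter of compound 3.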